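This account rests on a few compounds, and the source may have more. Where it says the series, first, only, none or still open, it means among the compounds named here.

Measured so far in a functional assay on the whole organism (strain Sprague-Dawley) for inhibition, with Rattus norvegicus as the target; a lower number here means that less compound is needed, a higher number that more compound is needed for the effect:

compound 1, `O=C(O)c1cnc2c(F)cccc2c1`: > 25 mg/kg
compound 2, `CCc1ccc2c(=O)c(-c3nn[nH]n3)c[nH]c2c1`: < 5 mg/kg
compound 3, `O=c1c(-c2nn[nH]n2)c[nH]c2ccccc12`: 1.25 mg/kg

Within the data shown here, compound 3 holds the only read number of the three; in this assay compound 3 gives 1.25 mg/kg. The value of compound 1 is a limit of the assay and not a number, the one described by the limit of > 25 mg/kg in this assay, at which 1 of the 3 values shown sits. The value of compound 2 is likewise a limit, the one described by the limit of < 5 mg/kg in this assay, at which 1 of the 3 values shown sits. Among the measured compounds shown here, the single step between measured compounds that differ in one place is a step that the limit leaves unreadable from compound 2 to compound 3, and the limit on compound 2 leaves its size unreadable, so nothing about the effect of a change on the shared core can be taken from it.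

Compound 4, `O=c1c(-c2nn[nH]n2)c[nH]c2ccc(F)cc12`, differs from compound 3 by fluoro in place of hydrogen on an aromatic carbon. For the measured compounds named here, no measured step concerns a fluoro on the core of compound 3; compound 1 carries a fluoro on a different core and its value is a limit, so it does not bear on this change either. Going by the values given here, with no step to lean on, the expectation is no change beyond the usual scatter, an expected step of no change at the digits printed from compound 3 to compound 4 (within the scatter) from the value of compound 3. Compound 4 is therefore estimated at 1.25 mg/kg in this assay, with an expected range of 0.5 mg/kg to 4 mg/kg.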

Compound 4, minimum effective dose: 1.25 mg/kg
Estimate against measurement, compound 4: no gap at the digits printed; the measured number falls inside the stated range.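

In this assay, fluoro in place of hydrogen on an aromatic carbon, meta to a fused ring and para to a fused ring, gives no change at the digits printed from compound 3 to compound 4 (within the scatter), so at this position the single fluorine atom is accommodated with no readable shift in minimum effective dose. Among these compounds, the only earlier step on the shared core cannot be read, as compound 2 stands at a limit, which makes this the first readable step and the first substitution on the core of compound 3 that can be judged against a number. Nothing recorded for these compounds accounts for the lack of change, and none of the recorded limits bears on this replacement.

Going by these compounds, whether a chloro, a methoxy or a trifluoromethyl on this same aromatic carbon would also leave the minimum effective dose unchanged stays open, as does the reading for fluoro on the other aromatic carbons of the shared core. Also open, on these data alone, is how an amine at this position would read, and how a carboxylic acid would read in place of the ring that the shared core carries.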